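A few compounds are considered here, and "the series" means these few. Any claim that something is new, unique, unknown or untested is made for them only; others in the source may bear on it.

Working notes on the series. Going by the values given here, compound 3 `CCC(C)(C)Cc1c[nH]c(CCc2ccc(-c3cccc(C#N)n3)cc2)n1` gives 140 nM in an in vitro assay on CHO cells for displacement of a labelled ligand from Bombesin receptor subtype-3 (Homo sapiens), read by scintillation counting, with a stated time of 2 h (on this read-out lower numbers stand for stronger inhibition and higher numbers for weaker inhibition), the highest number of the three measured members; the nearest is compound 2 `CCC(C)(C)Cc1c[nH]c(CCc2ccc(-c3csnn3)cc2)n1` at 45 nM, and the furthest is compound 1 `CCC(C)(C)Cc1c[nH]c(CCc2ccc(-c3cccc(N)n3)cc2)n1` at 7.3 nM. Both steps to compound 3 lie beyond the scatter, so compound 3 is the weakest binder so far.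

Compound 4 `CCC(C)(C)Cc1c[nH]c(CCc2ccc(-c3cccnc3C(=O)O)cc2)n1` is not yet measured. The change is 2-carboxypyridin-3-yl in place of 6-cyanopyridin-2-yl on an aromatic carbon. Among the compounds with values here, no measured pair swaps a cyano for a carboxy group, so the bearing of the earlier steps is indirect. The step of a 19-fold higher number from compound 1 to compound 3 (1.28 log units; beyond the scatter) shows that the substituent on the pyridine ring shifts the number a long way, with the hydrogen-bond donor bearing group at the strong end; the steps of a 6.2-fold higher number from compound 1 to compound 2 (0.79 log units; beyond the scatter) and a 3.1-fold higher number from compound 2 to compound 3 (0.49 log units; beyond the scatter) show that swapping the whole heteroaryl group moves it to a modest degree. A modest gain for compound 4 is therefore expected, within wide bounds, as a 1.8-fold lower number from compound 3 to compound 4 (0.24 log units; within the scatter). Compound 4 is estimated at 80 nM, with a range of 15 nM to 450 nM.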

Compound 4, half-maximal inhibitory concentration: 560 nM
For compound 4 the middle estimate is 7.0-fold (0.85 log units) below the measured one; measured number outside the range, above it.
By their numbers in this assay, from the lowest: compound 1; then compound 2; then compound 3; then compound 4.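

In this assay, going by these compounds alone, the swap to 2-carboxypyridin-3-yl gives a 4.0-fold higher number from compound 3 to compound 4 (0.60 log units; beyond the scatter), so this position can lose more than the earlier compounds showed, with the span widening to a 12-fold higher number from compound 2 to compound 4 (1.09 log units; beyond the scatter) and a 77-fold higher number from compound 1 to compound 4 (1.88 log units; beyond the scatter). All three steps lie beyond the scatter, which makes compound 4 the weakest binder of the four. The entering group carries a hydrogen-bond donor that the leaving group lacks, yet the number rises, so the donor-bearing group of compound 1 at the strong end does not make a rule, and compound 4 goes against one.

The data offer no explanation for this rise. The two group names differ in both substituent and pyridine attachment, so a 6-carboxypyridin-2-yl group or a primary carboxamide would be needed to separate these changes.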